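This account rests on a few compounds, and the source may have more. Where it says the series, first, only, none or still open, it means among the compounds named here.

Series notes. In an assay on isolated protein for binding affinity to 5-hydroxytryptamine receptor 6 (Homo sapiens) (on this read-out higher numbers stand for weaker inhibition and lower numbers for stronger inhibition), compound 1 `COc1cccc(-c2n[nH]cc2N2CCNCC2)c1` gives 269 nM; compound 2 `COc1ccc(-c2n[nH]cc2N2CCNCC2)cc1` gives 279 nM; compound 3 `c1ccc(-c2n[nH]cc2N2CCNCC2)cc1` gives 185 nM. Compound 3 sits at the low end of the three numbers, but both others fall within the scatter of it, so no separation among the three is established. Compound 4 `Clc1ccc(-c2n[nH]cc2N2CCNCC2)cc1` carries chloro in place of hydrogen on an aromatic carbon, para to a large group. Within the data shown here, the steps that bear on this change are a 1.5-fold lower number from compound 1 to compound 3 (0.16 log units; within the scatter) and a 1.5-fold lower number from compound 2 to compound 3 (0.18 log units; within the scatter); each concerns a single substituent on the same carbon-only ring, and neither moves this assay beyond the scatter. By analogy, the change to compound 4 is expected to give a 1.2-fold lower number from compound 3 to compound 4 (0.09 log units; within the scatter), nothing beyond the scatter. Compound 4 is therefore estimated at 150 nM, with a range of 60 nM to 400 nM.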

Compound 4, inhibition constant: 75 nM
Estimate against measurement, compound 4: 2.0-fold (0.30 log units) above; the measured number falls inside the stated range.
By their numbers in this assay, from the lowest: compound 4; then compounds 3, 1 and 2 (each within the scatter of the next).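

In this assay, among these compounds, chloro in place of hydrogen on the aromatic carbon para to a large group gives a 2.5-fold lower number from compound 3 to compound 4 (0.39 log units; beyond the scatter), the first step to pass beyond the scatter. Chloro in place of methoxy at that same place gives a 3.7-fold lower number from compound 2 to compound 4 (0.57 log units; beyond the scatter), so the substituent here can shift the number, which the methoxy compounds alone did not establish. No supporting data bear on the reason for these steps. Whether this is particular to chloro stays open, since bromo, fluoro or trifluoromethyl at this place are not among the compounds shown. Going by these compounds, the effect of chloro at the place held by methoxy in compound 1 is also open.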